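Swapping Fluoro for Chloro in a Noncytotoxic Pair

This account rests on a few compounds, and the source may have more. Where it says the series, first, only, none or still open, it means among the compounds named here.

- Compound 1 `COc1ccc2nc(NC(=O)c3cn(-c4ccccc4)nc3-c3ccc(F)cc3)sc2c1`: > 50000 nM (a limit)
- Compound 2 `Cc1ccc2nc(NC(=O)c3cn(-c4ccccc4)nc3-c3ccc(F)cc3)sc2c1`: > 50000 nM (a limit)

In an ADME assay on HEK-293T cells (Homo sapiens) for cytotoxicity, read by MTT assay, with a stated time of 72 h (on this read-out lower numbers stand for stronger inhibition and higher numbers for weaker inhibition), compound 1 gives > 50000 nM, which is a limit of the assay and not a number. Compound 2 also gives a limit, > 50000 nM. Both measured compounds therefore stand at the same point: the limit of > 50000 nM in this assay, at which 2 of the 2 values shown sit.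

Compound 3 `COc1ccc2nc(NC(=O)c3cn(-c4ccccc4)nc3-c3ccc(Cl)cc3)sc2c1` has not yet been measured. It differs from compound 1 in one place: chloro in place of fluoro on an aromatic carbon. This is chloro in place of fluoro on an aromatic carbon, para to a large group, so that 4-fluorophenyl becomes 4-chlorophenyl.

Among the compounds with values here, only one measured step is available as a guide: a step that the two limits leave unreadable from compound 1 to compound 2. It is a different exchange, methyl in place of methoxy, and its size cannot be read. It therefore gives no measured size for the new change, and no shift beyond the usual scatter is expected in either direction in this assay. The most likely result is another limit.

The estimated step is a number no higher from compound 1 to compound 3 (the limit leaves the size open). For compound 3 the expected value is 50000 nM, with an estimated range from 20000 nM to 100000 nM.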

Compound 3, half-maximal inhibitory concentration: 29600 nM
For compound 3 the middle estimate is 1.7-fold (0.23 log units) above the measured one; the range from low to high includes it.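

Within the data shown here, compound 3 is the only compound here that gives a true number and not a limit in this assay, so a single exchange of one halogen for another, at this one carbon of the phenyl ring, is enough to bring the reading inside the measurable range. The change from 4-fluorophenyl to 4-chlorophenyl amounts to an at least 1.6-fold lower number from compound 1 to compound 3 (0.22 log units; that floor lies within the scatter); the real gap could be larger, since only its lower bound can be read, but that bound alone does not show a change beyond ordinary variation between repeats. Even so, compound 3 stands apart from the rest of this small set, which stays at the ceiling of the assay: the limit of > 50000 nM in this assay, at which 2 of the 3 values shown sit.

The step between compound 1 and compound 2 cannot be read, so nothing shows whether the methoxy and methyl groups on the core influence this reading, or whether the same chloro exchange would give a number on compound 2. On these data alone, it also remains open how this carbon would respond to a larger or quite different group, such as bromo, trifluoromethyl, an amine or a carboxylic acid.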